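The source may report more compounds than this note shows. Statements on the series, on what has been measured and on what is new or still open speak of the compounds shown alone.

In a functional assay on HepG2 cells (Homo sapiens) for antiproliferative activity, read by MTT assay, with a stated time of 72 h (on this read-out lower numbers stand for stronger inhibition and higher numbers for weaker inhibition), compound 2 `O=c1nc2oc(CCCCl)cc2cn1Cc1cn(Cc2ccccc2)nn1` gives 27600 nM, the second highest of the three numbers shown. Its nearest neighbour is compound 3 `O=c1nc2oc(CCCCl)cc2cn1Cc1cn(-c2ccc(Cl)cc2)nn1`, which gives 89800 nM; the step of a 3.3-fold higher number from compound 2 to compound 3 (0.51 log units; beyond the scatter) comes from a 4-chlorophenyl in place of benzyl on an aromatic nitrogen and does not touch the place changed here. Among the compounds with values here, the furthest is compound 1 `O=c1nc2oc(C3CC3)c(C#CC3CC3)c2cn1Cc1cn(Cc2ccccc2)nn1`, which gives 2670 nM; it differs from compound 2 in two places, so its two values show only that the compound carrying a cyclopropyl sits far lower. Compound 4 `O=c1nc2oc(C3CC3)cc2cn1Cc1cn(Cc2ccccc2)nn1` differs from compound 2 by cyclopropyl in place of 3-chloropropyl on an aromatic carbon. Within the data shown here, no measured step isolates this change alone. Compound 4 is therefore expected to move toward a lower number, a step of a 3.5-fold lower number from compound 2 to compound 4 (0.54 log units; beyond the scatter). The estimated value of compound 4 is 8000 nM, with a range from 2500 nM to 25000 nM.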

Compound 4, half-maximal inhibitory concentration: 49100 nM
Beside the measured number, compound 4's estimate is 6.1-fold (0.79 log units) below it; measured number above the stated range.
By their numbers in this assay, from the lowest: compound 1; then compounds 2, 4 and 3 (each within the scatter of the next, the first and the last beyond it).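

In this assay, cyclopropyl in place of 3-chloropropyl on the aromatic carbon next to the ring oxygen gives a 1.8-fold higher number from compound 2 to compound 4 (0.25 log units; within the scatter), so the two groups are not told apart at this position. Hydrogen in place of 2-cyclopropylethynyl gives an 18-fold higher number from compound 1 to compound 4 (1.26 log units; beyond the scatter), so this large gap follows the 2-cyclopropylethynyl group, with cyclopropyl present on both sides of the step. Nothing available gives a reason for either step. From the compounds shown here alone, whether an amine or a longer chain next to the ring oxygen would separate from these two groups stays open. So does whether 2-cyclopropylethynyl would give a similar gap alongside 3-chloropropyl.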